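Chloro for methyl on the benzyl group: cytotoxicity notes

The source may report more compounds than this note shows. Statements on the series, on what has been measured and on what is new or still open speak of the compounds shown alone.

Measured so far in a toxicity assay on NIH3T3 cells (Mus musculus) for cytotoxicity, read by resazurin assay; a higher number here means that more compound is needed for the effect, a lower number that less compound is needed
Compound 1 `c1ccc(-c2ccc(Cn3cncc3CNc3cccc(-c4ccccc4)c3)cc2)cc1` gives 10000 nM.
Compound 2 `Clc1ccc(Cn2cncc2CNc2ccc(-c3nc4ccccc4s3)c(-c3ccccc3)c2)cc1` gives > 1000 nM, which is a limit.
Compound 3 `Cc1ccc(Cn2cncc2CNc2cccc(-c3ccccc3)c2)cc1` gives 10000 nM.

Compound 3 stands at 10000 nM, level with compound 1. Compound 4 `Clc1ccc(Cn2cncc2CNc2cccc(-c3ccccc3)c2)cc1` differs from it by chloro in place of methyl on an aromatic carbon, para to a large group, which gives 4-chlorobenzyl. Among the measured compounds shown here, the one measured step that bears on this, methyl in place of phenyl on an aromatic carbon, shows no change at the digits printed from compound 1 to compound 3 (within the scatter). On that basis, no step beyond the scatter is expected in this assay, and the estimated step is no change at the digits printed from compound 3 to compound 4 (within the scatter). For compound 4 the expected value is 10000 nM, with an estimated range of 3000 nM to 20000 nM.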

Compound 4, half-maximal effective concentration: 10000 nM
Compound 4: the middle estimate sits on the measured number at the digits printed, within the range that was stated.
By their numbers in this assay, from the lowest: compounds 1, 3 and 4 (each within the scatter of the next).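

In this assay, chloro in place of methyl on the benzyl group shows no change at the digits printed from compound 3 to compound 4 (within the scatter). Chloro in place of phenyl at the same aromatic carbon shows no change at the digits printed from compound 1 to compound 4 (within the scatter), so methyl, phenyl and chloro now all read alike at this place. Compound 2 gives a limit, and its step to compound 4 cannot be read: the limit of > 1000 nM in this assay, at which 1 of the 4 values shown sits.

From the compounds shown here alone, whether a carboxylic acid or an amine on this aromatic carbon would shift the value stays open. So does the effect of a longer chain here.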